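Chalcone aryl variation on the shared core

The source may hold more compounds than are shown below. What is called first, only, known or untested is meant among the compounds shown, and "the series" means these compounds.

compound 1 `CNC(=O)c1cc(Oc2ccc(C(=O)/C=C/c3ccc(F)cc3Cl)cc2)ccn1`: 21100 nM in a functional assay on MCF7 cells (Homo sapiens) for cytotoxicity, read by MTT assay, with a stated time of 72 h; on this read-out higher numbers stand for weaker inhibition and lower numbers for stronger inhibition
compound 2 `CNC(=O)c1cc(Oc2ccc(C(=O)/C=C/c3ccccc3)cc2)ccn1`: 5960 nM in this assay
compound 3 `CNC(=O)c1cc(Oc2ccc(C(=O)/C=C/c3ccc([N+](=O)[O-])cc3)cc2)ccn1`: "not determined" (no result reported) in this assay
compound 4 `CNC(=O)c1cc(Oc2ccc(C(=O)/C=C/c3ccc(Cl)c(Cl)c3)cc2)ccn1`: not yet measured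

Compound 1 stands highest of the two numbers in this assay; the nearest is compound 2, reached by a 3.5-fold lower number from compound 1 to compound 2 (0.55 log units; beyond the scatter). Compound 3 has no number. The change to compound 4 is 3,4-dichlorophenyl in place of 2-chloro-4-fluorophenyl on a double-bonded chain carbon bound to a double-bonded chain carbon. Going by the values given here, no measured step exchanges one substituted phenyl for another; the only step touching this place is a 3.5-fold lower number from compound 1 to compound 2 (0.55 log units; beyond the scatter), which ends in the bare phenyl. Compound 4 keeps a substituted ring with two chlorine, so a step of that full size is not expected; a modest fall, about at the edge of the scatter, is estimated, a 1.8-fold lower number from compound 1 to compound 4 (0.25 log units; within the scatter). Compound 4 is therefore expected near 12000 nM in this assay, within 4000 nM to 40000 nM.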

Compound 4, half-maximal inhibitory concentration: 13200 nM
For compound 4 the middle estimate is 1.1-fold (0.04 log units) below the measured one, within the range that was stated.
By their numbers in this assay, from the lowest: compound 2; then compounds 4 and 1 (each within the scatter of the next).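

In this assay, exchanging one dihalogenated phenyl for another at this place gives a 1.6-fold lower number from compound 1 to compound 4 (0.20 log units; within the scatter), so 2-chloro-4-fluorophenyl and 3,4-dichlorophenyl are not separated here. Set against the bare phenyl, 3,4-dichlorophenyl gives a 2.2-fold higher number from compound 2 to compound 4 (0.35 log units; beyond the scatter), so a second halogen-bearing ring also stands on the higher side of compound 2. No available data explain this result.

Going by these compounds, whether a phenyl carrying an amine or a carboxylic acid at this place also gives a higher number than compound 2 remains open.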